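Trimethoxyphenyl triazoles: a dichlorophenyl variant at the limit

The compounds below may be only part of what the source reports. "The series", "measured", "known", "first", "only" and "open" are said of these compounds alone.

In a functional assay on K562 cells (Homo sapiens) for antiproliferative activity, read by MTT assay, with a stated time of 72 h (a higher number here means a weaker inhibitor, a lower number a stronger inhibitor), compound 1, `COc1cc(-n2ncnc2-c2ccc(F)cc2)cc(OC)c1OC`, gives only the limit > 10000 nM.
In this assay compound 2, `COc1cc(-c2ncnn2-c2cccc([N+](=O)[O-])c2)cc(OC)c1OC`, gives only the limit > 10000 nM.
In this assay compound 3, `COc1cc(-c2ncnn2-c2ccc(N)cc2)cc(OC)c1OC`, gives only the limit > 10000 nM.

For the measured compounds named here, compound 1 thus stands at the limit of > 10000 nM in this assay, at which 3 of the 3 values shown sit, so no ranking among the three is possible and no step between measured compounds can be counted. Compound 4, `COc1cc(-n2ncnc2-c2ccc(Cl)c(Cl)c2)cc(OC)c1OC`, differs from compound 1 as follows: 3,4-dichlorophenyl in place of 4-fluorophenyl on an aromatic carbon. Since every measured value is a limit, nothing shown indicates that a change at this position moves the value. The step from compound 1 to compound 4 is expected to be no more than the scatter, that is a step that the limit leaves unreadable from compound 1 to compound 4. Compound 4 is therefore estimated at 15000 nM, in a range from 4000 nM to 60000 nM, most likely reported as a limit again.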

Compound 4, half-maximal inhibitory concentration: > 10000 nM
Compound 4 ended at the assay's limit (the forecaster's own chance of this, stated with the estimate: 75%); the middle value lies beyond the limit too.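

No step from compound 1 to compound 4 can be read in this assay, as both values are limits: the limit of > 10000 nM in this assay, at which 4 of the 4 values shown sit.

The compounds shown leave open which change to the shared core, if any, would give a value inside that limit.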